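Chloro Added to an Amide Analogue: Expected Toxicity

This account rests on a few compounds, and the source may have more. Where it says the series, first, only, none or still open, it means among the compounds named here.

Of the compounds shown here, two sharing one core have been tested in a functional assay on SW-620 cells (Homo sapiens) for inhibition, read by sulforhodamine B assay, with a stated time of 48 h; on this read-out higher numbers stand for lower toxicity in this test and lower numbers for higher toxicity in this test. Compound 1 `COc1cc(-c2nn(-c3cccc(NC(=O)Nc4cc(C(F)(F)F)cc(C(F)(F)F)c4)c3)cc2-c2ccncc2)ccc1Cl` gives 4870 nM in this assay. Compound 2 `COc1cc(-c2nn(-c3cccc(NC(=O)c4cccc(C(F)(F)F)c4)c3)cc2-c2ccncc2)ccc1Cl` reaches only the limit of this test, > 50000 nM, so no number is known for it. Compound 2 thus stands at the limit of > 50000 nM in this assay, at which 1 of the 2 values shown sits, and its true value is open. Compound 3 `COc1cc(-c2nn(-c3cccc(NC(=O)c4ccc(Cl)c(C(F)(F)F)c4)c3)cc2-c2ccncc2)ccc1Cl` is not yet measured; it differs from compound 2 by chloro in place of hydrogen on an aromatic carbon, which, cut one bond further out, reads as 3-(trifluoromethyl)phenyl to 4-chloro-3-(trifluoromethyl)phenyl. Among the measured compounds shown here, no step between measured compounds is at hand, so the effect of this change cannot be read from earlier results. The expected step is an at least 1.1-fold lower number from compound 2 to compound 3 (0.04 log units; that floor lies within the scatter), most likely none beyond the usual scatter. Compound 3 is therefore estimated at 45000 nM, within a range from 15000 nM to 100000 nM, with a fair chance that only a limit is again reported.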

Compound 3, concentration lethal to 50% of the cells: > 32500 nM
Compound 3 ended at the assay's limit; the forecaster's own chance of this, stated with the estimate: 55%; the middle value lies beyond the limit too.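

Among the compounds shown here, no step from compound 2 to compound 3 can be read, since each is reported in this assay only as a limit and not as a number. The compounds shown leave open whether chloro in place of hydrogen changes this read-out at all, and in which direction.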